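Trading a dimethylamino aryl for a dimethylphenyl group

The compounds below may be only part of what the source reports. "The series", "measured", "known", "first", "only" and "open" are said of these compounds alone.

Compound 2 `CC(C)c1cccc(C(C)C)c1NC(=O)NCC1(c2cccc(N(C)C)c2)CCCC1` gives 33 nM in an assay on microsomes for inhibition of acyl-CoA:cholesterol acyltransferase (Oryctolagus cuniculus) (a lower number here means a stronger inhibitor, a higher number a weaker inhibitor), the highest of the two numbers shown, though its distance from compound 1 `CC(C)c1cccc(C(C)C)c1NC(=O)NCC1(c2ccc(N)cc2)CCCC1`, which gives 29 nM, lies within the scatter. Within the data shown here, that lone step, a 1.1-fold higher number from compound 1 to compound 2 (0.06 log units; within the scatter), is the only measured change touching the aryl group on the saturated ring carbon. Compound 3 `Cc1ccc(C2(CNC(=O)Nc3c(C(C)C)cccc3C(C)C)CCCC2)c(C)c1` carries 2,4-dimethylphenyl in place of 3-(dimethylamino)phenyl on a saturated ring carbon. Among the measured compounds shown here, because the only comparable aryl exchange, a 1.1-fold higher number from compound 1 to compound 2 (0.06 log units; within the scatter), stayed within the scatter, compound 3 is expected to show no step beyond the scatter, a 1.2-fold higher number from compound 2 to compound 3 (0.08 log units; within the scatter). Compound 3 is estimated at 40 nM, with a range from 15 nM to 110 nM.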

Compound 3, half-maximal inhibitory concentration: 50 nM
The estimate for compound 3 lay 1.3-fold (0.10 log units) below the measured number; the measured number falls inside the stated range.
By their numbers in this assay, from the lowest: compounds 1, 2 and 3 (each within the scatter of the next).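

In this assay, exchanging the 3-(dimethylamino)phenyl for 2,4-dimethylphenyl gives a 1.5-fold higher number from compound 2 to compound 3 (0.18 log units; within the scatter) and the comparison with the 4-aminophenyl of compound 1 gives a 1.7-fold higher number from compound 1 to compound 3 (0.24 log units; within the scatter) as well. On this saturated ring carbon, then, an aryl group without nitrogen remains within the scatter of both nitrogen-bearing aryl groups. No accompanying measurement bears on this result.

The compounds shown leave open whether a carboxylic acid on this aryl group would also stay within the scatter. Nor do they show how an unsubstituted phenyl would compare.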